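Removing One Methoxy Group on a Pyrazole Chalcone Series

The source may report more compounds than this note shows. Statements on the series, on what has been measured and on what is new or still open speak of the compounds shown alone.

Compound 1, `COc1cc(-c2cc(/C=C/C(=O)c3ccc(N)cc3)[nH]n2)cc(OC)c1OC`: > 100000 nM
Compound 2, `COc1ccc(-c2cc(/C=C/C(=O)c3ccc(N)cc3)[nH]n2)cc1OC`: 73000 nM
Compound 3, `COc1cc(C(=O)/C=C/c2cc(-c3cc(OC)c(OC)c(OC)c3)n[nH]2)cc(OC)c1OC`: 33100 nM

All three were tested in a functional assay on IGROV-1 cells (Homo sapiens) for inhibition, read by sulforhodamine B assay, with a stated time of 48 h; on this read-out higher numbers stand for lower toxicity in this test and lower numbers for higher toxicity in this test. For compound 1 the result is a limit of the assay rather than a number: > 100000 nM. Compound 2 gives 73000 nM and compound 3 gives 33100 nM, the lower of the two numbers obtained. Compound 2 arises from compound 1 by a single change, (hydrogen in place of methoxy on an aromatic carbon), and the measured step is an at least 1.3-fold lower number from compound 1 to compound 2 (0.13 log units; that floor lies within the scatter); its floor comes from the limit of > 100000 nM in this assay, at which 1 of the 3 values shown sits.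

Compound 4, `COc1ccc(-c2cc(/C=C/C(=O)c3cc(OC)c(OC)c(OC)c3)[nH]n2)cc1OC`, has not yet been measured. It arises from compound 3 by the same kind of change, (hydrogen in place of methoxy on an aromatic carbon), at a place described in the same words. How the core of compound 3 differs from that of compound 1 is not broken down here.

Because the step of an at least 1.3-fold lower number from compound 1 to compound 2 (0.13 log units; that floor lies within the scatter) sits within the scatter, compound 4 is expected to land close to compound 3. The expected step is a 1.3-fold lower number from compound 3 to compound 4 (0.10 log units; within the scatter). The value estimated for compound 4 in this assay is 26000 nM, likely between 10000 nM and 65000 nM.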

Compound 4, concentration lethal to 50% of the cells: 46700 nM
For compound 4 the middle estimate is 1.8-fold (0.25 log units) below the measured one, and the stated range covers the measured number.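

On the core of compound 3, putting hydrogen in place of a methoxy group gives, in this assay, a 1.4-fold higher number from compound 3 to compound 4 (0.15 log units; within the scatter), so this pair shows no clear difference between the two compounds. Setting this result beside the same change on the core of compound 1 gives the following picture: the same change on two cores in this assay, an at least 1.3-fold lower number (0.13 log units; that floor lies within the scatter) from compound 1 to compound 2 and a 1.4-fold higher number (0.15 log units; within the scatter) from compound 3 to compound 4; the limit leaves it open whether they differ. The pair on the core of compound 3 therefore offers no sign that the change matters there, but it cannot show whether the change behaves the same way on the core of compound 1, as the result for compound 1 is a limit rather than a number: the limit of > 100000 nM in this assay, at which 1 of the 4 values shown sits.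

The compounds shown leave open whether a hydroxy group, a chlorine atom or an amine in place of that methoxy group would give a step beyond the scatter. They also leave open how the change compares across two cores when both pairs give numbers rather than a limit.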